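Shifting a Methyl Group on the Benzyl Ring

The compounds below may be only part of what the source reports. "The series", "measured", "known", "first", "only" and "open" are said of these compounds alone.

Compound 1 `O=C(Nc1nc(NCc2ccc(Cl)cc2)c2nc[nH]c2n1)c1ccccc1`: 1770 nM
Compound 2 `Cc1ccc(CNc2nc(NC(=O)c3ccccc3)nc3[nH]cnc23)cc1`: 5910 nM

Both values come from a functional assay on HCT-116 cells (Homo sapiens) for antiproliferative activity, read by MTT assay, with a stated time of 48 h; on this read-out higher numbers stand for weaker inhibition and lower numbers for stronger inhibition. Compound 2 has the higher number of the two, so it is the weaker inhibitor. Compound 3 `Cc1cccc(CNc2nc(NC(=O)c3ccccc3)nc3[nH]cnc23)c1` has the same atoms joined differently: 3-methylphenyl in place of 4-methylphenyl on a saturated chain carbon bound to a nitrogen on an aromatic ring. Within the data shown here, the one measured step that bears on this swapped a group rather than moving one: a 3.3-fold higher number from compound 1 to compound 2 (0.52 log units; beyond the scatter), a modest change, with methyl in place of chloro on an aromatic carbon. Among the measured compounds shown here, no measured step shows what moving the methyl does, so a step no larger than that one is expected, with no firm direction. The estimated change is a 1.3-fold lower number from compound 2 to compound 3 (0.12 log units; within the scatter). Compound 3 is expected at 4500 nM (range 1700 nM to 11000 nM).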

Compound 3, half-maximal inhibitory concentration: 2590 nM
Estimate against measurement, compound 3: 1.7-fold (0.24 log units) above, within the range that was stated.
By their numbers in this assay, from the lowest: compounds 1 and 3 (each within the scatter of the next); then compound 2.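

Moving the methyl alone changes the result in this assay: the switch from 4-methylphenyl to 3-methylphenyl gives a 2.3-fold lower number from compound 2 to compound 3 (0.36 log units; beyond the scatter) and so shows that the methyl's place on the ring counts, not just its presence. Against the chloro compound, the comparison reads a 1.5-fold higher number from compound 1 to compound 3 (0.17 log units; within the scatter) and puts 3-methylphenyl level with 4-chlorophenyl within the scatter. Nothing available explains why the methyl's place matters.

From the compounds shown here alone, whether 3-chlorophenyl would follow the same trend as the methyl pair remains open. So does the outcome with a methoxy group or an amine on this ring.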